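Amine variation on a thiocarbonyl carbon: working notes

The compounds below may be only part of what the source reports. "The series", "measured", "known", "first", "only" and "open" are said of these compounds alone.

Measured so far:
- Compound 1 `CCOC(=O)c1cc(=O)c2cc(CSC(=S)N(C)c3ccccc3)ccc2o1`: in a functional assay on LM7 cells (Homo sapiens) for antiproliferative activity, read by MTT assay, with a stated time of 72 h (on this read-out higher numbers stand for weaker inhibition and lower numbers for stronger inhibition), compound 1 gives > 25000 nM, a limit of the assay rather than a number.
- Compound 2 `COc1ccc2occ(CSC(=S)N(C(C)C)C(C)C)c(=O)c2c1`: in this assay compound 2 gives 4700 nM.
- Compound 3 `O=c1cc(CSC(=S)N2CCCC2)oc2cc(Cl)ccc12`: in this assay compound 3 gives > 25000 nM, again a limit.

Among the measured compounds shown here, compound 2 thus stands alone as the only number in the set; the other two sit at the limit of > 25000 nM in this assay, at which 2 of the 3 values shown sit. For the measured compounds named here, no pair among the measured compounds differs in a single place, so no measured step is available.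

Compound 4 `COc1ccc2occ(CSC(=S)N3CCOCC3)c(=O)c2c1` carries the change (morpholin-4-yl in place of diisopropylamino on a thiocarbonyl carbon). Going by the values given here, with no comparable step in hand, the expectation is a step from compound 2 of a 1.5-fold higher number from compound 2 to compound 4 (0.17 log units; within the scatter), that is, a modest weakening if anything, hardly beyond the scatter. For compound 4 in this assay the estimate is 7000 nM, with a range from 2500 nM to 25000 nM.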

Compound 4, half-maximal inhibitory concentration: > 40000 nM
Compound 4: no number, only a limit; the forecaster's own chance of this, stated with the estimate: 25%; at least 5.7-fold (0.75 log units) between middle value and limit.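

In this assay, among the compounds shown here, morpholin-4-yl in place of diisopropylamino on a thiocarbonyl carbon gives an at least 8.5-fold higher number from compound 2 to compound 4 (0.92 log units; beyond the scatter), the first step that is beyond the scatter. For the compounds shown here, the amine on this carbon therefore matters on an otherwise unchanged core, which the earlier compounds could not show. Compound 4 sits at a limit of the assay, so the step is a bound and not a size: the limit of > 40000 nM in this assay, at which 1 of the 4 values shown sits.

The compounds shown do not separate the effect of losing the open branched chain from that of bringing in the ring oxygen. Piperidin-1-yl or diethylamino on the core of compound 2 would address that question.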